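Indole for Phenyl: Expected Solubility of Compound 4

This account rests on a few compounds, and the source may have more. Where it says the series, first, only, none or still open, it means among the compounds named here.

Compound 2 `CNC(=O)c1cc(C(=O)NC2CC2)cc2c1OC[C@H]2c1ccccc1` carries a phenyl group on a saturated ring carbon of its shared core. In a physicochemical assay for solubility (on this read-out higher numbers stand for higher solubility and lower numbers for lower solubility), compound 2 gives only a limit of the assay, >= 190 ug/mL. Compound 1 `CNC(=O)c1cc(C(=O)NC2CC2)cc2c1O[C@H](CF)[C@H]2c1ccccc1`, which bears a fluoromethyl group at that carbon, gives 8 ug/mL, and the step is an at least 23-fold higher number from compound 1 to compound 2 (1.37 log units; beyond the scatter). Compound 3 `CNC(=O)c1cc(C(=O)N[C@H]2[C@@H]3C[C@@H](O)C[C@@H]32)cc2c1OC[C@H]2c1ccccc1` likewise gives only a limit, >= 124 ug/mL. The step is a step that the two limits leave unreadable from compound 2 to compound 3. Compound 4 `CNC(=O)c1cc(C(=O)NC2CC2)cc2c1OC[C@H]2c1cccc2[nH]ccc12` differs from compound 2 by 1H-indol-4-yl in place of phenyl on a saturated ring carbon. Neither measured step alters the aryl group, so none bears directly on this change, and compound 2 itself stands only at a limit. The expected step is an at least 1.9-fold lower number from compound 2 to compound 4 (0.27 log units; that floor lies within the scatter). Compound 4 is estimated at 100 ug/mL, within 30 ug/mL to 250 ug/mL.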

Compound 4, solubility: >= 142 ug/mL
Compound 4 ended at the assay's limit; the forecaster's own chance of this, stated with the estimate: 40%; at least 1.4-fold (0.15 log units) between middle value and limit.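

Within the data shown here, compound 2 and compound 4 both give only a limit in this assay, so no step between them can be read. The compounds shown leave open whether 1H-indol-4-yl in place of phenyl shifts this read-out, and in which direction.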